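Swapping chloro for tert-butyl on compound 2

The source may report more compounds than this note shows. Statements on the series, on what has been measured and on what is new or still open speak of the compounds shown alone.

In an ADME assay on HCT-116 cells (Homo sapiens) for antiproliferative activity (a lower number here means a stronger inhibitor, a higher number a weaker inhibitor), compound 1 (`COc1ccc(C#N)cc1COc1ccc(Cl)c(C)c1`) reaches only a limit of the assay, > 50000 nM. Compound 2 (`COc1ccc(C(N)=O)cc1/C=C/c1ccc(Cl)cc1`) gives 7100 nM, the lower of the two actual numbers, while compound 3 (`COc1ccc(C(N)=O)cc1/C=C\c1ccc(Cl)cc1`) gives 29000 nM. Compound 4 (`COc1ccc(C(N)=O)cc1/C=C/c1ccc(C(C)(C)C)cc1`) has tert-butyl in place of chloro on an aromatic carbon, para to a large group: tert-butyl in place of chloro on an aromatic carbon. Among the measured compounds shown here, the one measured step, a 4.1-fold higher number from compound 2 to compound 3 (0.61 log units; beyond the scatter), changes only the double-bond configuration and does not touch this group, so it offers only a rough guide to size. A modest move towards a higher number is therefore expected, with the estimated step being a 1.7-fold higher number from compound 2 to compound 4 (0.23 log units; within the scatter). Compound 4 is expected at 12000 nM, within an estimated range of 3500 nM to 40000 nM.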

Compound 4, half-maximal inhibitory concentration: 20000 nM
Beside the measured number, compound 4's estimate is 1.7-fold (0.22 log units) below it; the range from low to high includes it.
By their numbers in this assay, from the lowest: compound 2; then compounds 4 and 3 (each within the scatter of the next). At a limit, above all of these: compound 1.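

In this assay tert-butyl in place of chloro gives a 2.8-fold higher number from compound 2 to compound 4 (0.45 log units; beyond the scatter) and so shows that this aromatic carbon, para to a large group, is sensitive to the change of substituent. The earlier step altered only the double-bond configuration, so it said nothing about this position. Nothing on hand accounts for this step.

On these data alone, whether a methoxy group or an amine here would give a number lower than that of compound 2 stays open. So does whether the same swap would behave alike on compound 3.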